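Swapping Methoxy for Cyanomethyl in Compound 2

The source may hold more compounds than are shown below. What is called first, only, known or untested is meant among the compounds shown, and "the series" means these compounds.

Within the data shown here, in an ADME assay on HEp-2 cells (Homo sapiens) for cytotoxicity (on this read-out lower numbers stand for higher toxicity in this test and higher numbers for lower toxicity in this test), compound 2 (`COCc1cccc2c1nc(Cn1c(=O)n(C(C)C)c3ccccc31)n2CCC(C)C`) gives 26700 nM, the higher of the two numbers measured so far, while compound 1 (`CC(C)CCn1c(Cn2c(=O)n(C(C)C)c3ccccc32)nc2c(CN)cccc21`) gives 7000 nM. Compound 3 (`CC(C)CCn1c(Cn2c(=O)n(C(C)C)c3ccccc32)nc2c(CCC#N)cccc21`) has cyanomethyl in place of methoxy on a saturated chain carbon bound to an aromatic carbon. Among the measured compounds shown here, only one measured step bears on this place, a 3.8-fold higher number from compound 1 to compound 2 (0.58 log units; beyond the scatter), with methoxy in place of amino. For the measured compounds named here, that step is modest, and no measured compound carries cyanomethyl, so it offers only a rough scale. Compound 3, like compound 2, lacks the amino group of compound 1, so no clear move back toward the lower number is expected. The estimated step is a 1.2-fold lower number from compound 2 to compound 3 (0.08 log units; within the scatter), expected to stay within the scatter. In this assay, compound 3 is expected at 22000 nM, with an estimated range from 9000 nM to 50000 nM.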

Compound 3, half-maximal cytotoxic concentration: 2240 nM
Estimate against measurement, compound 3: 9.8-fold (0.99 log units) above, outside the stated range (below it).
By their numbers in this assay, from the lowest: compound 3; then compound 1; then compound 2.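

Among these compounds, at this place, on a saturated chain carbon bound to an aromatic carbon, the group can shift the result more than the single earlier step showed: in this assay, cyanomethyl in place of methoxy gives a 12-fold lower number from compound 2 to compound 3 (1.08 log units; beyond the scatter), a large step. Losing the amino group does not by itself bring a higher number, since cyanomethyl in place of amino gives a 3.1-fold lower number from compound 1 to compound 3 (0.49 log units; beyond the scatter), which leaves the amino compound in the middle of the three. Nothing available explains why these groups order the compounds this way.

As far as these compounds go, it remains open whether the low number goes with the nitrile itself or with the longer chain that carries it. A plain propyl chain at this place, or a carboxylic acid, would help to separate those two readings.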